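Benzoyl Exchanged for Trifluoromethylphenylamino on the Shared Core

This account rests on a few compounds, and the source may have more. Where it says the series, first, only, none or still open, it means among the compounds named here.

For the measured compounds named here, compound 1 `O=C(Nc1cccc(-c2nc(-c3ccc(NC(=O)c4cccnc4)cc3Cl)no2)c1)c1ccccc1` is the one member of this small set with a number of its own: in a functional assay on MDA-MB-231 cells (Homo sapiens) for antiproliferative activity, read by MTT assay, with a stated time of 72 h (on this read-out lower numbers stand for stronger inhibition and higher numbers for weaker inhibition), compound 1 gives 12800 nM. Compound 2 `O=C(Nc1ccc(-c2noc(-c3cccc(NS(=O)(=O)c4ccccc4)c3)n2)c(Cl)c1)c1cccnc1` carries phenylsulfonyl in place of benzoyl on a nitrogen on an aromatic ring; in this assay compound 2 gives only a limit, > 10000 nM. Compound 3 `O=C(Nc1ccc(-c2noc(-c3cccc(NS(=O)(=O)c4ccc(NC(=O)N5CCCCC5)cc4)c3)n2)c(Cl)c1)c1cccnc1` adds ((piperidin-1-yl)carbonyl)amino on an aromatic carbon; in this assay compound 3 likewise gives only a limit, > 10000 nM. The step that the limit leaves unreadable from compound 1 to compound 2 and the step that the two limits leave unreadable from compound 2 to compound 3 therefore cannot be sized, because the limit of > 10000 nM in this assay, at which 2 of the 3 values shown sit, hides both.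

Compound 4 `O=C(Nc1cccc(-c2nc(-c3ccc(NC(=O)c4cccnc4)cc3Cl)no2)c1)Nc1cccc(C(F)(F)F)c1` differs from compound 1 by (3-(trifluoromethyl)phenyl)amino in place of phenyl on a carbonyl carbon. Going by the values given here, no measured step touches this change, and the two steps that exist stay unreadable, so there is no ground for expecting movement in this assay beyond the scatter in either direction. The estimate for compound 4 is thus a step of a 1.4-fold lower number from compound 1 to compound 4 (0.15 log units; within the scatter), close to no change. Compound 4 is expected to give about 9000 nM, within 2500 nM and 35000 nM.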

Compound 4, half-maximal inhibitory concentration: 1900 nM
The estimate for compound 4 lay 4.7-fold (0.68 log units) above the measured number, outside the stated range (below it).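

For the compounds shown here, on the carbonyl carbon whose other neighbour is an amide-type nitrogen, this exchange gives the only readable step in the set, in this assay: a 6.7-fold lower number from compound 1 to compound 4 (0.83 log units; beyond the scatter). It shows that the group on this carbonyl carbon can move the number beyond the scatter, which the earlier compounds could not show, because the other two steps cannot be read: the limit of > 10000 nM in this assay, at which 2 of the 4 values shown sit.

The entering (3-(trifluoromethyl)phenyl)amino differs from phenyl in both its amino link and its trifluoromethyl group, and this single step does not separate the two. A plain phenylamino group would tell them apart, but it is not among the compounds shown. As far as these compounds go, how a carboxylic acid on that aromatic ring, or a longer alkylamino chain on the carbonyl carbon, would read also stays open.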